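The source may hold more compounds than are shown below. What is called first, only, known or untested is meant among the compounds shown, and "the series" means these compounds.

In a functional assay on DLD-1 cells (Homo sapiens) for antiproliferative activity, read by CellTiter-Glo, with a stated time of 72 h (on this read-out lower numbers stand for stronger inhibition and higher numbers for weaker inhibition), compound 1 (`Cc1noc(C)c1S(=O)(=O)N1CCC(N2CCC(C)CC2)CC1`) gives > 5000 nM, which is a limit of the assay and not a number. Among the compounds with values here, compound 2 (`CC1CCN(C2CCN(S(=O)(=O)c3cnc(Cl)s3)CC2)CC1`) gives 1800 nM, the only actual number so far. Compound 3 (`CC1CCN(C2CCN(S(=O)(=O)c3nccn3C)CC2)CC1`) carries 1-methyl-1H-imidazol-2-yl in place of 2-chloro-1,3-thiazol-5-yl on a sulfonyl sulfur. Within the data shown here, one measured step bears on this change, because an at least 2.7-fold lower number from compound 1 to compound 2 (0.44 log units; beyond the scatter) also exchanges the group on the sulfonyl sulfur, and it lies beyond the scatter. That step brought in the 2-chloro-1,3-thiazol-5-yl group that compound 3 now gives up, so a return towards weaker inhibition in this assay seems likely. The expected change is a 2.2-fold higher number from compound 2 to compound 3 (0.35 log units; beyond the scatter), towards a higher number. For compound 3 the estimated value is 4000 nM, with an expected range from 1500 nM to 11000 nM.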

Compound 3, half-maximal inhibitory concentration: > 5000 nM
Compound 3: a limit, no number; the forecaster's own chance of this, stated with the estimate: 50%; at least 1.2-fold (0.09 log units) between middle value and limit.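

In this assay, putting 1-methyl-1H-imidazol-2-yl in place of 2-chloro-1,3-thiazol-5-yl on the sulfonyl sulfur gives an at least 2.7-fold higher number from compound 2 to compound 3 (0.44 log units; beyond the scatter). Compound 3 gives > 5000 nM, which is a limit of the assay and not a number, so the size of this step is only a minimum, yet it shows that two groups with the same counts of heavy atoms, hydrogen-bond donors and acceptors are not interchangeable here. The step from compound 1 to compound 3 cannot be read because both values are limits: the limit of > 5000 nM in this assay, at which 2 of the 3 values shown sit.

As far as these compounds go, how far compound 1 and compound 3 lie beyond that limit remains open, so their two groups cannot be ranked. Also open, from the compounds shown here alone, is what a plain 1,3-thiazol-5-yl without the chlorine, or a phenyl group, would give on the same sulfonyl sulfur.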